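Methoxy removal at two places in a short series

The compounds below may be only part of what the source reports. "The series", "measured", "known", "first", "only" and "open" are said of these compounds alone.

Measured in a functional assay on A549 cells (Homo sapiens) for cytotoxicity, read by MTT assay, with a stated time of 48 h; a lower number here means a stronger inhibitor, a higher number a weaker inhibitor:
compound 1 `COc1ccc(-c2cc(C(=O)Nc3nc4ccc(Cl)cc4s3)nc3cc(-c4ccccc4)nn23)cc1` gives 3090 nM
compound 2 `COc1ccc(-c2cc(C(=O)Nc3nc4ccc(Cl)cc4s3)nc3cc(-c4ccccc4)nn23)cc1OC` gives 6160 nM
compound 3 `COc1ccc(-c2cc(C(=O)Nc3nc4ccc(OC)cc4s3)nc3cc(-c4ccccc4)nn23)cc1` gives 17400 nM

Compound 4 `COc1ccc(-c2cc(C(=O)Nc3nc4ccccc4s3)nc3cc(-c4ccccc4)nn23)cc1` is not yet measured. The change from compound 2 to compound 1 is hydrogen in place of methoxy on an aromatic carbon and gave a 2.0-fold lower number from compound 2 to compound 1 (0.30 log units; within the scatter). Compound 3 and compound 4 differ by hydrogen in place of methoxy on an aromatic carbon; the difference between the cores of compound 2 and compound 3 is not broken down here. The two changes are the same kind of change, not the same: in compound 2 the place is ortho to a methoxy group and meta to a large group, in compound 3 it is part of a fused system of two rings, meta and para to a fused ring. The step of a 5.6-fold higher number from compound 1 to compound 3 (0.75 log units; beyond the scatter) sets compound 3 apart. For compound 4 the expected step is a 2.2-fold lower number from compound 3 to compound 4 (0.34 log units; beyond the scatter), resting on the step from compound 2 to compound 1 being small while compound 1 sits lower at 3090 nM. Compound 4 is estimated at 8000 nM, between 3000 nM and 20000 nM.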

Compound 4, half-maximal inhibitory concentration: 1540 nM
Compound 4: the middle estimate sits 5.2-fold (0.72 log units) above what was measured; the whole stated range lies above it.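

Removing a methoxy group does not carry over as one fixed step between these cores in this assay: the same change on two cores in this assay, a 2.0-fold lower number (0.30 log units; within the scatter) from compound 2 to compound 1 and an 11-fold lower number (1.05 log units; beyond the scatter) from compound 3 to compound 4, 5.7-fold (0.75 log units) apart, beyond the scatter of two such steps

On the 1,3-benzothiazol-2-yl part, methoxy removal gives an 11-fold lower number from compound 3 to compound 4 (1.05 log units; beyond the scatter), while hydrogen in place of chloro at that same place gives a 2.0-fold lower number from compound 1 to compound 4 (0.30 log units; within the scatter), so in this set only the methoxy group there separates from the other two. This does not show why the steps differ, since the two changes sit at different places as well as on different cores, and neither can be separated from the other here.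

From the compounds shown here alone, whether an amine or a carboxylic acid at that place would track methoxy or chloro remains open. So does the step for removing the methoxy group that compound 1 and compound 4 share.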